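The compounds below may be only part of what the source reports. "The series", "measured", "known", "first", "only" and "open" are said of these compounds alone.

Compound 1, whose structure is `O=C(NO)c1ccc(-c2cn([C@@H]3C[C@@H](C(=O)O)N(Cc4ccccc4)C3)nn2)cc1`, was tested in an assay on Sf9 cells for inhibition of histone deacetylase 11 (Homo sapiens), read by fluorescence, tested at 0.5 uM; a higher number here means more inhibition at the concentration tested (going by the name of the read-out), a lower number less inhibition. In this assay compound 1 gives < 10%, which is a limit of the assay rather than a measured number. A second compound, compound 2 with structure `O=C(NO)c1cccc(-c2cn([C@@H]3C[C@@H](C(=O)O)N(Cc4ccccc4)C3)nn2)c1`, carries the 3-(hydroxycarbamoyl)phenyl in place of the 4-(hydroxycarbamoyl)phenyl on an aromatic carbon. In this assay compound 2 gives < 10%, again a limit and not a number. The step from one to the other is therefore a step that the two limits leave unreadable from compound 1 to compound 2; both values sit at the limit of < 10% in this assay, at which 2 of the 2 values shown sit.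

The compound yet to be measured, compound 3 with structure `O=C(NO)c1ccc(-c2cn([C@H]3C[C@H](C(=O)O)N(Cc4ccccc4)C3)nn2)cc1`, differs from compound 1 in this way: the two compounds have the same atoms and bonds and differ only in configuration as drawn: 2 of 2 stereo elements differ (all stereocentres are inverted: mirror images); a stereocentre at a saturated ring carbon is drawn R in compound 1 and S in compound 3; a stereocentre at a saturated ring carbon is drawn S in compound 1 and R in compound 3. Among the compounds with values here, no measured step concerns a change of configuration alone, and the only measured step, from compound 1 to compound 2, cannot be read in size. Within the data shown here, the two values so far both lie at the limit, so no step beyond the scatter is expected in this assay from compound 1 to compound 3, and the expected step is a step that the limit leaves unreadable from compound 1 to compound 3. Compound 3 is estimated at 5%, within a range from 0% to 15%.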

Compound 3, a percentage reported as inhibition, at one concentration (the size of the read-out at that concentration, not a potency): < 10%
Compound 3: a limit, no number; the forecaster's own chance of this, stated with the estimate: 80%; the middle value lies beyond the limit too.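

In this assay compound 3 gives < 10%, which is a limit of the assay and not a number. The step between compound 1 and compound 3 therefore cannot be read: the limit of < 10% in this assay, at which 3 of the 3 values shown sit.

The compounds shown leave open whether inverting both stereocentres changes inhibition at all, as none of them gives a readable number.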